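The compounds below may be only part of what the source reports. "The series", "measured", "known", "first", "only" and "open" are said of these compounds alone.

Measured so far:
- compound 1, `O=C1O[C@H]([C@@H](O)Cn2cc(CNS(=O)(=O)c3ccc(F)cc3)nn2)C(OCc2ccccc2)=C1OCc1ccccc1`: 41100 nM
- compound 2, `CC(C)(C)c1cn(C[C@H](O)[C@H]2OC(=O)C(OCc3ccccc3)=C2OCc2ccccc2)nn1`: 35800 nM

Both compounds share a lactone core carrying two benzyloxy groups and a hydroxypropyl-linked triazole; they differ only in the group on the triazole ring. In a functional assay on SW-620 cells (Homo sapiens) for antiproliferative activity, read by MTT assay, with a stated time of 72 h (on this read-out lower numbers stand for stronger inhibition and higher numbers for weaker inhibition), compound 1 gives 41100 nM and compound 2 gives 35800 nM. Compound 2 holds the lowest of the two numbers, but the step of a 1.1-fold lower number from compound 1 to compound 2 (0.06 log units; within the scatter) is within the scatter, so the two cannot be told apart.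

Compound 3, `O=C1O[C@H]([C@@H](O)Cn2cc(CNS(=O)(=O)c3ccc(Cl)cc3)nn2)C(OCc2ccccc2)=C1OCc1ccccc1`, has not yet been measured in this assay. It differs from compound 2 by (((4-chlorophenyl)sulfonyl)amino)methyl in place of tert-butyl on an aromatic carbon. Compound 1 carries the closely related fluoro group at the same place, and its step to compound 2 was a 1.1-fold lower number from compound 1 to compound 2 (0.06 log units; within the scatter); nothing beyond the scatter is therefore expected from compound 2 to compound 3, a step estimated at a 1.1-fold higher number from compound 2 to compound 3 (0.05 log units; within the scatter). The estimate for compound 3 in this assay is 40000 nM, with a range from 18000 nM to 90000 nM.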

Compound 3, half-maximal inhibitory concentration: 18000 nM
For compound 3 the middle estimate is 2.2-fold (0.35 log units) above the measured one; measured number inside the range.
By their numbers in this assay, from the lowest: compounds 3, 2 and 1 (each within the scatter of the next, the first and the last beyond it).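

In this assay, among the compounds shown here, chloro in place of fluoro gives a 2.3-fold lower number from compound 1 to compound 3 (0.36 log units; beyond the scatter); the step is modest, but it is the first at this position to stand clear of the scatter, so exchanging a single atom on the aromatic ring of this group can be read here. Exchanging the whole group gives a 2.0-fold lower number from compound 2 to compound 3 (0.30 log units; within the scatter), so tert-butyl and (((4-chlorophenyl)sulfonyl)amino)methyl still cannot be told apart on this aromatic carbon, even though they differ greatly in size. Nothing available explains the difference between chloro and fluoro.

The compounds shown leave open whether bromo or methoxy in place of chloro would extend the step seen with chloro. They also leave open how a group of another kind on the same aromatic carbon, such as an amine or a carboxylic acid, would compare.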